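From chloromethyl to prop-1-en-1-yl on an amide carbonyl

The source may report more compounds than this note shows. Statements on the series, on what has been measured and on what is new or still open speak of the compounds shown alone.

Of the compounds shown here, three have been measured so far in a functional assay on Maver1 cells (Homo sapiens) for inhibition, read by luminescence and CellTiter-Glo, with a stated time of 72 h; on this read-out lower numbers stand for stronger inhibition and higher numbers for weaker inhibition. Compound 3 `O=C(O)c1cc(-c2ccc(Oc3ccccc3)cc2)nn1C1CCCN(C(=O)CCl)C1` gives 400 nM, the lowest number of the three. Compound 1 `O=C(CCl)N1CCCC(n2nc(-c3ccc(Oc4ccccc4)cc3)cc2CO)C1` gives 1100 nM, and compound 2 `C/C=C/C(=O)Nc1cccc(Cn2nc(-c3ccc(Oc4ccccc4)cc3)cc2C(=O)O)c1` gives 31600 nM.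

The next compound to be tested, compound 4 `C/C=C/C(=O)N1CCCC(n2nc(-c3ccc(Oc4ccccc4)cc3)cc2C(=O)O)C1`, differs from compound 3 in one group: prop-1-en-1-yl in place of chloromethyl on a carbonyl carbon. Put simply, prop-1-en-1-yl takes the place of chloromethyl on a carbonyl carbon whose other neighbours are an amide-type nitrogen in a ring.

Among the compounds with values here, no measured step makes this exact change. Within the data shown here, the only step available, a 2.8-fold lower number from compound 1 to compound 3 (0.44 log units; beyond the scatter), is modest and replaces hydroxymethyl with carboxy on an aromatic carbon, so it offers no direct guide. The closest hint comes from compound 2, which also carries prop-1-en-1-yl on a carbonyl carbon and gives 31600 nM. Compound 2 also differs from compound 3 in other ways, so it is only a loose guide, and it points towards weaker inhibition.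

The expected change is a 3.8-fold higher number from compound 3 to compound 4 (0.57 log units; beyond the scatter), a move towards weaker inhibition. For compound 4, the estimated value is 1500 nM, with an expected range from 400 nM to 8000 nM.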

Compound 4, half-maximal inhibitory concentration: > 60000 nM
Compound 4: a limit, no number; the forecaster's own chance of this, stated with the estimate: 5%; at least 40-fold (1.60 log units) between middle value and limit.
By their numbers in this assay, from the lowest: compound 3; then compound 1; then compound 2. At a limit, above all of these: compound 4.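

Within the data shown here, the group on the amide carbonyl carries far more weight than the earlier compounds could show. In this assay, among these compounds, exchanging chloromethyl for prop-1-en-1-yl on a carbonyl carbon gives an at least 150-fold higher number from compound 3 to compound 4 (2.17 log units; beyond the scatter), whereas the only earlier one-place change, hydroxymethyl to carboxy on an aromatic carbon, gives just a 2.8-fold lower number from compound 1 to compound 3 (0.44 log units; beyond the scatter). The result for compound 4 is a limit of the assay and not a number: the limit of > 60000 nM in this assay, at which 1 of the 4 values shown sits.

Only these two groups appear on this carbonyl carbon in a matched pair, so this single exchange cannot separate the loss of the chlorine from the gain of a double bond or the slightly larger size of the entering group. On these data alone, an ethenyl group, or a saturated chain such as propyl, would help to separate these, and it also remains open whether prop-1-en-1-yl would behave the same way in the hydroxymethyl series of compound 1.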